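Methoxy to methyl on the compound 3 scaffold

The source may report more compounds than this note shows. Statements on the series, on what has been measured and on what is new or still open speak of the compounds shown alone.

In a functional assay on A549 cells (Homo sapiens) for antiproliferative activity, read by MTT assay, with a stated time of 48 h (on this read-out higher numbers stand for weaker inhibition and lower numbers for stronger inhibition), compound 3 (`COc1ccc2[nH]c(-c3cn(-c4ccccc4)nc3-c3ccc(F)cc3)nc2c1`) gives 1960 nM. This is the middle of three numbers, but it lies within the scatter of both compound 2 (`Fc1ccc(-c2nn(-c3ccccc3)cc2-c2nc3cc(Cl)ccc3[nH]2)cc1`) at 1320 nM and compound 1 (`Cc1ccc2[nH]c(-c3cn(-c4ccccc4)nc3-c3ccccc3)nc2c1`) at 3610 nM.

Compound 4 (`Cc1ccc2[nH]c(-c3cn(-c4ccccc4)nc3-c3ccc(F)cc3)nc2c1`) is the next step: methyl in place of methoxy on an aromatic carbon.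

Among the measured compounds shown here, only one measured step exchanges this methoxy: a 1.5-fold higher number from compound 2 to compound 3 (0.17 log units; within the scatter), with chloro as the other group. Since that step stays within the scatter, this substituent has not yet shown a clear effect on the numbers in this assay. Compound 1 also carries the methyl but differs elsewhere, so its 3610 nM is only a loose guide, though it leaves some room for a higher number.

The expected step, a 1.2-fold higher number from compound 3 to compound 4 (0.07 log units; within the scatter), stays within the scatter, with no firm direction. The estimate for compound 4 is 2300 nM, with an expected range of 1200 nM to 4300 nM.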

Compound 4, half-maximal inhibitory concentration: 1440 nM
Beside the measured number, compound 4's estimate is 1.6-fold (0.20 log units) above it; the range from low to high includes it.
By their numbers in this assay, from the lowest: compounds 2, 4, 3 and 1 (each within the scatter of the next, the first and the last beyond it).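

In this assay the two new steps at this aromatic carbon, a 1.4-fold lower number from compound 3 to compound 4 (0.13 log units; within the scatter) and a 1.1-fold higher number from compound 2 to compound 4 (0.04 log units; within the scatter), both stay within the scatter, so methyl, methoxy and chloro now form a set of three groups with no clear separation at this position on the fluoro-bearing scaffold. Among the compounds shown here, the first step beyond the scatter lies at another place: a 2.5-fold lower number from compound 1 to compound 4 (0.40 log units; beyond the scatter) is modest and comes from fluoro in place of hydrogen on an aromatic carbon, with methyl held constant. No evidence on the cause of either result is available.

On these data alone, whether an amine or a carboxylic acid on this aromatic carbon would move the number beyond the scatter remains open. Also open is whether the fluoro step holds with methoxy or chloro in place of methyl, as no hydrogen counterpart of compound 2 or compound 3 is shown.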